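The compounds below may be only part of what the source reports. "The series", "measured", "known", "first", "only" and "open" are said of these compounds alone.

Measured compounds:
- compound 1 `Nc1ncnc2c1nc(O)n2Cc1ccc(F)cc1`: 10 uM
- compound 2 `Nc1nc(N)c2nc(O)n(Cc3ccccc3)c2n1`: 10 uM

In a functional assay (spleen, spleen) for activation, with Mus musculus as the target (a higher number here means that more compound is needed for the effect, a lower number that less compound is needed), compound 1 gives 10 uM. Compound 2 gives 10 uM in this assay, and the two values stand level at the digits shown, within the usual scatter of the measurement, so neither can be called more or less active than the other on these numbers.

Compound 3 `Nc1ncnc2c1nc(O)n2Cc1ccccc1` has not yet been measured in this assay. It is reached from compound 1 by a single change on the benzyl group: hydrogen in place of fluoro on an aromatic carbon. The rest of the molecule, the shared core of compound 1, is untouched.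

For the measured compounds named here, no measured pair in this set differs only in this fluoro group, so the size of the step cannot be read off directly. Given that compound 1 and compound 2 sit at the same value, the expectation is that this small change makes no difference beyond the scatter, with the step of no change at the digits printed from compound 1 to compound 3 (within the scatter) expected to be about nothing. Compound 3 is therefore estimated at 10 uM in this assay, expected to fall between 3 uM and 30 uM.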

Compound 3, minimum effective concentration: 10 uM
Estimate against measurement, compound 3: no gap at the digits printed; the measured number falls inside the stated range.
By their numbers in this assay, from the lowest: compounds 1, 2 and 3 (each within the scatter of the next).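

In this assay, for the compounds shown here, removing the fluoro group from the benzyl group gives no change at the digits printed from compound 1 to compound 3 (within the scatter) and so provides the first direct reading at this position, on an aromatic carbon para to a large group. Compound 3 also forms a single-change pair with compound 2, where removing the amino group gives no change at the digits printed from compound 2 to compound 3 (within the scatter) and shows that this second site can also change without moving the value beyond the scatter. No separate measurement is available to explain why either change leaves the value level.

These three compounds show no spread in activity, so they do not reveal which parts of the structure matter for the effect in the mouse spleen. As far as these compounds go, it remains open whether a methoxy group or a carboxylic acid at the fluoro position, an amine or a longer chain at the amino position, or replacement of the benzyl group itself would shift the minimum effective concentration.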